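Series notes: from compound 2 to compound 4

This account rests on a few compounds, and the source may have more. Where it says the series, first, only, none or still open, it means among the compounds named here.

Measured compounds:
compound 1, `O=C(Nc1ccc(Cl)cc1)NS(=O)(=O)c1ccc(Cl)s1`, 58%
compound 2, `COc1ccc(S(=O)(=O)NC(=O)Nc2ccc(Cl)cc2)s1`, 93%
compound 3, `CCCOc1ccc(S(=O)(=O)NC(=O)Nc2ccc(Cl)cc2)s1`, 44%

All three were run in a functional assay on the whole organism (6C3HED cells, Mus musculus) for inhibition, at a dose of 150 mg/kg by the oral route; on this read-out higher numbers stand for more inhibition at the one dose given (going by the name of the read-out) and lower numbers for less inhibition. Compound 2 stands highest of the three; compound 1 is the nearest, with a number 35 percentage points higher from compound 1 to compound 2 (beyond the scatter), and compound 3 the furthest, with a number 49 percentage points lower from compound 2 to compound 3 (beyond the scatter). Compound 4, `CCc1ccc(S(=O)(=O)NC(=O)Nc2ccc(Cl)cc2)o1`, is not yet measured. It differs from compound 2 in one place: 5-ethylfuran-2-yl in place of 5-methoxythiophen-2-yl on a sulfonyl sulfur. Going by the values given here, no measured step matches this change exactly. Two bear on it: the methoxy group, which compound 4 loses, accounted for a number 35 percentage points higher from compound 1 to compound 2 (beyond the scatter), and lengthening the chain on the ring oxygen gave a number 49 percentage points lower from compound 2 to compound 3 (beyond the scatter), while compound 3 against compound 1 shows a number 14 percentage points lower from compound 1 to compound 3 (beyond the scatter). Both considerations point downward, so a large fall is expected in this assay, a number 43 percentage points lower from compound 2 to compound 4 (beyond the scatter). Compound 4 is estimated at 50%, between 25% and 75%.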

Compound 4, a percentage reported as inhibition, in the whole organism at one dose (the size of the read-out at that dose, not a potency): 57%
Estimate against measurement, compound 4: 7 percentage points below, and the stated range covers the measured number.
By their numbers in this assay, from the lowest: compound 3; then compounds 4 and 1 (each within the scatter of the next); then compound 2.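

In this assay the exchange of 5-methoxythiophen-2-yl for 5-ethylfuran-2-yl on a sulfonyl sulfur gives a number 36 percentage points lower from compound 2 to compound 4 (beyond the scatter) and so does not keep the high number of compound 2. Set against 5-chlorothiophen-2-yl, the same group gives a number 1 percentage points lower from compound 1 to compound 4 (within the scatter) and is not distinguished from it at this position. Nothing available explains either step. Going by these compounds, in compound 4 the ring and its substituent change together, so which of them carries the fall stays open. On these data alone, how an amine or a carboxylic acid on this ring would compare also stays open.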